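From nitro to amino at the assay limit

The compounds below may be only part of what the source reports. "The series", "measured", "known", "first", "only" and "open" are said of these compounds alone.

- Compound 1 `O=[N+]([O-])c1ccc(-c2nc3cc(C(F)(F)F)ccc3[nH]2)cc1`: 6000 nM
- Compound 2 `Cn1c(-c2ccc([N+](=O)[O-])cc2)nc2cc(C(F)(F)F)ccc21`: >= 100000 nM

In an ADME assay on MT4 cells (Homo sapiens) for cytotoxicity, read by MTT assay, with a stated time of 96 h (on this read-out higher numbers stand for lower toxicity in this test and lower numbers for higher toxicity in this test), compound 2 gives no number, only a limit: it stands at the limit of >= 100000 nM in this assay, at which 1 of the 2 values shown sits. Compound 3 `Cn1c(-c2ccc(N)cc2)nc2cc(C(F)(F)F)ccc21` has amino in place of nitro on an aromatic carbon. Among the compounds with values here, the single measured step, an at least 16-fold higher number from compound 1 to compound 2 (1.22 log units; beyond the scatter), was large, but it is methyl in place of hydrogen on an aromatic nitrogen, so it does not size this change. A number from this limit can only fall, so a modest move downward is expected, though compound 3 may reach the limit too. The expected step is an at least 2.0-fold lower number from compound 2 to compound 3 (0.30 log units; that floor lies within the scatter). Compound 3 is estimated at 50000 nM, with an expected range from 10000 nM to 100000 nM.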

Compound 3, half-maximal cytotoxic concentration: 20000 nM
Beside the measured number, compound 3's estimate is 2.5-fold (0.40 log units) above it; low and high end bracket the measured number.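

In this assay, amino in place of nitro on an aromatic carbon gives an at least 5.0-fold lower number from compound 2 to compound 3 (0.69 log units; beyond the scatter). This is the only change shown at this position, and it shows that the read-out responds to the group there, with the amino compound giving a number rather than a limit. Compound 2 holds only a limit of the assay, so the step has a floor but no full size: the limit of >= 100000 nM in this assay, at which 1 of the 3 values shown sits.

From the compounds shown here alone, whether a carboxylic acid or an acetamide at this position would give a number remains open. So does the size of the amino change on compound 1, which has hydrogen in place of methyl on the aromatic nitrogen.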